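Phenyl in Place of tert-Butyl on the Shared Core

This account rests on a few compounds, and the source may have more. Where it says the series, first, only, none or still open, it means among the compounds named here.

Measured compounds:
compound 1 `CC(C)(C)c1cc(N)c2cc(NC(=O)/C=C/c3ccc(C(F)(F)F)cc3)ccc2n1` gives 29 nM
compound 2 `CCCc1cc(N)c2cc(NC(=O)/C=C/c3ccc(CC)cc3)ccc2n1` gives 160 nM
compound 3 `CCCc1cc(N)c2cc(NC(=O)/C=C/c3ccc(Cl)cc3)ccc2n1` gives 96 nM

In a functional assay on HEK293 cells for activation of melanin-concentrating hormone receptor 1 (Homo sapiens), read by inositol phosphate accumulation (on this read-out lower numbers stand for an effect already at smaller amounts and higher numbers for an effect only at larger amounts of compound), compound 1 gives the lowest number of the three, and the gaps from compound 1 to compound 3 and to compound 2 both lie beyond the scatter. Among the measured compounds shown here, the only step between measured compounds that differ in one place is a 1.7-fold lower number from compound 2 to compound 3 (0.22 log units; within the scatter), which concerns the group on the distant aryl ring of the acrylamide and not the position changed here.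

Compound 4 `Nc1cc(-c2ccccc2)nc2ccc(NC(=O)/C=C/c3ccc(C(F)(F)F)cc3)cc12` is compound 1 with phenyl in place of tert-butyl on an aromatic carbon. For the measured compounds named here, no measured step touches that position: compound 2 and compound 3 carry propyl there and differ from compound 1 in two places at once, so their values show only that both stand beyond the scatter from compound 1 without separating the two changes. The expectation for compound 4 therefore rests on the observation that the shared core tolerates at least two different groups at this position, and the estimate is a step of a 1.4-fold higher number from compound 1 to compound 4 (0.14 log units; within the scatter) in this assay, which is not expected to exceed the scatter by much in either direction. Compound 4 is thus estimated at 40 nM, with a range from 12 nM to 130 nM.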

Compound 4, half-maximal effective concentration: 6600 nM
The estimate for compound 4 lay 170-fold (2.22 log units) below the measured number; measured number above the stated range.
By their numbers in this assay, from the lowest: compound 1; then compounds 3 and 2 (each within the scatter of the next); then compound 4.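

In this assay, the change at this aromatic carbon next to the ring nitrogen is a 230-fold higher number from compound 1 to compound 4 (2.36 log units; beyond the scatter), with the rest of compound 1 left as it is. Among the compounds shown here, this is the first reading of this position alone, and it shows that the position does not accept every group: the earlier compounds carried only tert-butyl or propyl there, and none differed from another in this place alone. Nothing at hand gives a cause for a step of this size.

Going by these compounds, it remains open whether the large step belongs to phenyl alone or also extends to other rings at this position, such as cyclohexyl or pyridyl, and whether a smaller group such as methyl or an amine would stay close to compound 1. Also open, on these data alone, is how propyl compares with tert-butyl when the trifluoromethyl group on the distant aryl ring is held fixed, as compound 2 and compound 3 differ from compound 1 in two places at once.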